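Fluoro to Bromo Swap and Paw Edema Inhibition

The source may hold more compounds than are shown below. What is called first, only, known or untested is meant among the compounds shown, and "the series" means these compounds.

Compound 1 `O=C1N/C(=N\c2nccs2)S/C1=C\c1cccc(F)c1` gives 56.6%
Compound 2 `O=C1N/C(=N\c2nccs2)S/C1=C\c1ccc(F)cc1` gives 65.6%
Compound 3 `O=C1N/C(=N\c2nccs2)S/C1=C\c1cccc(Br)c1` gives 42.7%

All three were tested in a functional assay on the whole organism (strain AKR) for inhibition, with Mus musculus as the target, read by paw edema, with a stated time of 3.5 h, at a dose of 0.01 mmol/kg by the intraperitoneal route; on this read-out lower numbers stand for less inhibition and higher numbers for more inhibition at the one dose given (going by the name of the read-out). Compound 2 has the highest number of the three; its gap to compound 1 lies within the scatter, while its gap to compound 3 lies beyond it. Compound 1 and compound 2 have the same atoms joined differently; the difference between the two cores is not broken down here. From compound 1 to compound 3 the change is bromo in place of fluoro on an aromatic carbon, and it produced a number 13.9 percentage points lower from compound 1 to compound 3 (beyond the scatter). Compound 4 `O=C1N/C(=N\c2nccs2)S/C1=C\c1ccc(Br)cc1` is not yet measured. It differs from compound 2 by bromo in place of fluoro on an aromatic carbon. This is the same kind of change, though the place differs: meta to a large group in the first pair, para to a large group in the second. Set beside the earlier step, compound 4 is expected to show a number 13.6 percentage points lower from compound 2 to compound 4 (beyond the scatter) in this assay, resting on a number 13.9 percentage points lower from compound 1 to compound 3 (beyond the scatter). The estimate for compound 4 is 52%, expected to fall between 38% and 66%.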

Compound 4, a percentage reported as inhibition, in the whole organism at one dose (the size of the read-out at that dose, not a potency): 42.2%
Compound 4: middle estimate off by 9.8 percentage points, on the high side, and the stated range covers the measured number.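

In this assay, bromo in place of fluoro on an aromatic carbon gave a number 23.4 percentage points lower from compound 2 to compound 4 (beyond the scatter). The change therefore lowered the number on both cores, and the two steps do not differ beyond what repeated measurements would allow: the same change on two cores in this assay, a number 13.9 percentage points lower (beyond the scatter) from compound 1 to compound 3 and a number 23.4 percentage points lower (beyond the scatter) from compound 2 to compound 4, 9.5 percentage points apart, within the scatter of two such steps This supports carrying the step between these two cores in this assay, but two pairs do not show that it would hold on other cores, and they do not explain why the number falls.

The compounds shown carry only fluoro or bromo on this ring, so the effect of chloro, methoxy or an amine there remains open. Also open, from the compounds shown here alone, is whether the step would hold at other doses.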